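Changing one aromatic group on a shared core

The source may report more compounds than this note shows. Statements on the series, on what has been measured and on what is new or still open speak of the compounds shown alone.

Values in a functional assay on HepG2 cells (Homo sapiens) for antiproliferative activity, read by sulforhodamine B assay, with a stated time of 48 h; a lower number here means a stronger inhibitor, a higher number a weaker inhibitor:
Compound 1 `COc1cccc(/C=C/C(=O)C(=Cc2ccc(F)cc2)C(=O)/C=C/c2cccc(OC)c2OC)c1OC` – 580 nM
Compound 2 `COc1ccc(C=C(C(=O)/C=C/c2cccc(OC)c2OC)C(=O)/C=C/c2cccc(OC)c2OC)cc1OC` – 200 nM
Compound 3 `COc1cccc(/C=C/C(=O)C(=Cc2cc(OC)c(OC)c(OC)c2)C(=O)/C=C/c2cccc(OC)c2OC)c1OC` – 220 nM

Compound 3 sits among the lower numbers of this small set. The step of a 1.1-fold higher number from compound 2 to compound 3 (0.04 log units; within the scatter) shows no real difference, whereas the step of a 2.6-fold lower number from compound 1 to compound 3 (0.42 log units; beyond the scatter) is a modest but real one.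

Compound 4 `COc1cc(C=C(C(=O)/C=C/c2cccc(OC)c2OC)C(=O)/C=C/c2cccc(OC)c2OC)cc(Br)c1O` keeps the shared core and changes one group: 3-bromo-4-hydroxy-5-methoxyphenyl in place of 3,4,5-trimethoxyphenyl on a double-bonded chain carbon bound to a double-bonded chain carbon. The closest evidence comes from swaps at this same place. Besides the two steps above, there is the step of a 2.9-fold lower number from compound 1 to compound 2 (0.46 log units; beyond the scatter), also modest. For the measured compounds named here, no measured compound carries bromine or a hydroxy group, so this evidence is indirect. Going by the values given here, the only measured halogen-bearing group is in compound 1, which gives 580 nM, so a slight drift towards a higher number is expected, though probably nothing clearly beyond the scatter in this assay. The estimated change is a 1.3-fold higher number from compound 3 to compound 4 (0.10 log units; within the scatter). Compound 4 is expected to give about 280 nM, with an estimated range of 110 nM to 700 nM.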

Compound 4, half-maximal inhibitory concentration: 240 nM
Beside the measured number, compound 4's estimate is 1.2-fold (0.07 log units) above it; low and high end bracket the measured number.
By their numbers in this assay, from the lowest: compounds 2, 3 and 4 (each within the scatter of the next); then compound 1.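

In this assay, the 3-bromo-4-hydroxy-5-methoxyphenyl group, the only one here carrying bromine and a hydroxy group, shows no real difference from 3,4,5-trimethoxyphenyl at this position (a 1.1-fold higher number from compound 3 to compound 4 (0.04 log units; within the scatter)). It also shows no real difference from 3,4-dimethoxyphenyl (a 1.2-fold higher number from compound 2 to compound 4 (0.08 log units; within the scatter)), yet it stays apart from 4-fluorophenyl (a 2.4-fold lower number from compound 1 to compound 4 (0.38 log units; beyond the scatter)), so a halogen on this ring does not by itself go with the higher number of compound 1. No measurement at hand accounts for why these groups compare as they do.

Bromine and the hydroxy group appear only together, so what each contributes alone remains open. Also open, on these data alone, is how an amine, a carboxylic acid or a longer chain at this place would read in this assay.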